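This account rests on a few compounds, and the source may have more. Where it says the series, first, only, none or still open, it means among the compounds named here.

Measured so far in a physicochemical assay for solubility, in phosphate buffer, measured as kinetic solubility (on this read-out lower numbers stand for lower solubility and higher numbers for higher solubility), the series reads as follows.
compound 1 `CC(C)C(CC1C(=O)NC(=O)N1C)c1ccc(-c2ccc3cccc(F)c3c2)[nH]c1=O` gives 33600 nM
compound 2 `C/C(=C1/OC(=O)NC1=O)C(c1ccc(-c2ccc3cccc(F)c3c2)[nH]c1=O)C(C)C` gives 17200 nM
compound 3 `CC(C)/C(=C1/SC(=O)NC1=O)c1ccc(-c2ccc3cccc(F)c3c2)[nH]c1=O` gives 23300 nM

Compound 2 at 17200 nM sits within the scatter of compound 1 and of compound 3, so the three values do not separate.

Compound 4 `CC(C)C(/C=C1/C(=O)NC(=O)N1C)c1ccc(-c2ccc3cccc(F)c3c2)[nH]c1=O` is not yet measured. Against compound 2 it shows a group of 9 heavy atoms (5 carbon, 2 nitrogen, 2 oxygen; one five-membered non-aromatic ring with 2 hetero atoms) in place of a group of 9 heavy atoms (5 carbon, 1 nitrogen, 3 oxygen; one five-membered non-aromatic ring with 2 hetero atoms), on a saturated chain carbon bound to an aromatic carbon and a saturated chain carbon on a saturated chain carbon bound to an aromatic carbon and a saturated chain carbon.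

Within the data shown here, one measured step bears on this exchange. The step of a 2.0-fold lower number from compound 1 to compound 2 (0.29 log units; within the scatter) runs between groups of the same counts in the opposite direction, and it stays within the scatter. Among the measured compounds shown here, the group in compound 1 is not identical to the one in compound 4, so that step is a guide and not a direct reading.

No step beyond the scatter is therefore expected in this assay here. The estimated step of a 1.4-fold higher number from compound 2 to compound 4 (0.14 log units; within the scatter) is expected to stay within the scatter. The estimate for compound 4 is 24000 nM with an expected range from 10000 nM to 50000 nM in four of five readings.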

Compound 4, solubility: 34800 nM
Compound 4: middle estimate off by 1.5-fold (0.16 log units), on the low side; the measured number falls inside the stated range.
By their numbers in this assay, from the lowest: compounds 2, 3, 1 and 4 (each within the scatter of the next, the first and the last beyond it).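

In this assay, the exchange on a saturated chain carbon bound to an aromatic carbon and a saturated chain carbon gives a 2.0-fold higher number from compound 2 to compound 4 (0.31 log units; beyond the scatter), so this position now shows a step beyond the scatter, though only a modest one. The two groups with equal atom counts do not separate, since a 1.0-fold higher number from compound 1 to compound 4 (0.02 log units; within the scatter) stays within the scatter, and at this place the atom counts of the group go with the read-out only as far as these four compounds show. No measurement at hand accounts for either step.

Going by these compounds, whether a different kind of group at this place, such as an amine or a carboxylic acid, would move the number further than these five-membered rings remains open. On these data alone, the effect of a longer chain carrying the same ring is also open.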